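A few compounds are considered here, and "the series" means these few. Any claim that something is new, unique, unknown or untested is made for them only; others in the source may bear on it.

Measured in a functional assay on MCF7 cells (Homo sapiens) for inhibition, read by MTT assay, with a stated time of 48 h; a lower number here means a stronger inhibitor, a higher number a weaker inhibitor:
compound 1 `O=C(CC(c1ccc(F)cc1)C(C(=O)Nc1ccccn1)C(=O)Nc1ccccn1)c1ccccc1`: 20900 nM
compound 2 `O=C(CC(c1ccc([N+](=O)[O-])cc1)C(C(=O)Nc1ccccn1)C(=O)Nc1ccccn1)c1ccccc1`: "not active" (no number reported)

Compound 2 has no single number in this assay: its entry reads "not active" (no number reported). Going by the values given here, no measured step therefore connects it with compound 1, and the only numerical anchor is compound 1 at 20900 nM.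

The next structure, compound 3 `O=C(CC(c1c(Cl)cccc1Cl)C(C(=O)Nc1ccccn1)C(=O)Nc1ccccn1)c1ccccc1`, has not yet been measured. The change under consideration is 2,6-dichlorophenyl in place of 4-nitrophenyl on a saturated chain carbon bound to two saturated chain carbons, with 2,6-dichlorophenyl in place of 4-nitrophenyl on a saturated chain carbon bound to two saturated chain carbons. The rest of the shared core stays the same.

Without a number for compound 2, the size of this step in this assay cannot be set with any precision. If a number is obtained at all, the expected direction is towards a stronger result than that of compound 2, and the number is expected to lie close to the result of compound 1, which is 20900 nM. A result without a number also remains a real possibility. The estimated value for compound 3 is 25000 nM, with an expected range of 8000 nM to 80000 nM.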

Compound 3, half-maximal inhibitory concentration: 16700 nM
Estimate against measurement, compound 3: 1.5-fold (0.18 log units) above; the range from low to high includes it.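

In this assay, placing 2,6-dichlorophenyl instead of 4-fluorophenyl on the saturated chain carbon bound to two saturated chain carbons gives a 1.3-fold lower number from compound 1 to compound 3 (0.10 log units; within the scatter), so these two aryl groups are not told apart at this position. Compound 3 at 16700 nM provides a second number at this position and shows that a numerical result does not depend on the 4-fluorophenyl group, while compound 2, with 4-nitrophenyl, remains the only one of the three without a number, so the change from it to 2,6-dichlorophenyl cannot be sized. No measurement bearing on the reason for these results is available.

Going by these compounds alone, with only three aryl groups at this position, it remains open whether the 4-nitrophenyl result is specific to the nitro group or would recur with another substituent, such as an amine or a carboxylic acid on the phenyl ring. Going by these compounds, it is also open whether an unsubstituted phenyl or a phenyl ring bearing a single chlorine would stay level with compound 1 and compound 3.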